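Swapping Chloro for Fluoro on the Shared Core

The compounds below may be only part of what the source reports. "The series", "measured", "known", "first", "only" and "open" are said of these compounds alone.

- Compound 1 `C=CC(=O)Nc1cccc(Nc2nc(Nc3ccc(OCC(=O)N4CCCC4C(=O)OC)cc3)ncc2Cl)c1`: 4800 nM
- Compound 2 `C=CC(=O)Nc1cccc(Nc2nc(Nc3ccc(Cn4cc(C)nc4CC)cc3)ncc2Cl)c1`: < 10900 nM

In a functional assay on NAMALVA cells (Homo sapiens) for antiproliferative activity, read by CCK-8 assay, with a stated time of 72 h (a lower number here means a stronger inhibitor, a higher number a weaker inhibitor), compound 1 gives 4800 nM. Compound 2 stands at the limit of < 10900 nM in this assay, at which 1 of the 2 values shown sits, and this is a limit of the assay, not a number. Compound 1 and compound 2 differ in more than one place, so neither offers a measured guide to the next change.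

Compound 3 `C=CC(=O)Nc1cccc(Nc2nc(Nc3ccc(Cn4cc(C)nc4CC)cc3)ncc2F)c1` keeps the structure of compound 2 but has fluoro in place of chloro on an aromatic carbon. Among the measured compounds shown here, no measured pair shows this swap, so any forecast for it is uncertain. A small step towards a lower number in this assay is expected, and the estimated change is a step that the limit leaves unreadable from compound 2 to compound 3. For compound 3, the expected value is 6000 nM, with an estimated range of 2000 nM to 14000 nM.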

Compound 3, half-maximal inhibitory concentration: < 10900 nM
Compound 3: only a limit was reported (the forecaster's own chance of this, stated with the estimate: 25%); the middle value is on the limit's open side.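

Compound 2 and compound 3 each carry only a limit in this assay, not a number, so the step from chloro to fluoro cannot be read: the limit of < 10900 nM in this assay, at which 2 of the 3 values shown sit.

The compounds shown leave open how large this swap's change in this assay is, and in which direction it runs.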